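The compounds below may be only part of what the source reports. "The series", "measured", "known", "first", "only" and "open" are said of these compounds alone.

Working notes on the series. Compound 1 `Oc1ccccc1-c1cc(-c2ccc(F)cc2)cc(-c2ccccc2O)n1` has been tested in a functional assay on HCT-15 cells (Homo sapiens) for inhibition; a higher number here means a weaker inhibitor, a lower number a stronger inhibitor. In this assay compound 1 gives > 50000 nM, a limit of the assay rather than a number. Compound 2 `Oc1cccc(-c2cc(-c3cccc(F)c3)cc(-c3ccccc3O)n2)c1` carries a 3-hydroxyphenyl group and a 3-fluorophenyl group on the shared core. In this assay compound 2 gives > 50000 nM, again a limit and not a number. Among the measured compounds shown here, compound 2 therefore stands where every recorded value stands, at the limit of > 50000 nM in this assay, at which 2 of the 2 values shown sit; no step between measured compounds can be drawn, so nothing in hand separates one substitution pattern from another. Compound 3 `Oc1cccc(-c2cc(-c3ccc(F)cc3)cc(-c3ccccc3O)n2)c1` has not yet been measured and differs from compound 2 in one place: 4-fluorophenyl in place of 3-fluorophenyl on an aromatic carbon. With both known values sitting at a limit, the step from a step that the limit leaves unreadable from compound 2 to compound 3 is expected to be none beyond the scatter. Compound 3 is estimated at 60000 nM in this assay, within 20000 nM to 200000 nM, and most probably reported only as a limit.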

Compound 3, half-maximal inhibitory concentration: > 50000 nM
Compound 3 was reported as a limit; the forecaster's own chance of this, stated with the estimate: 85%; the middle value does not contradict the limit.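

Compound 3 also stands at a limit in this assay, so the steps to compound 3 from compound 1 and from compound 2 cannot be read: the limit of > 50000 nM in this assay, at which 3 of the 3 values shown sit.

The compounds shown leave open whether either change on the shared core affects inhibition at all.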